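The compounds below may be only part of what the source reports. "The series", "measured", "known", "first", "only" and "open" are said of these compounds alone.

In a functional assay on RXF 393 cells (Homo sapiens) for inhibition, read by sulforhodamine B assay, with a stated time of 48 h, tested at 0.01 uM (a lower number here means a stronger effect, a higher number a weaker effect of the compound at the concentration tested), compound 3, `COc1cc(Cl)cc(-c2nn(-c3cccc(NC(=O)Nc4ccc(Cl)c(C(F)(F)F)c4)c3)cc2-c2ccncc2)c1`, gives 97%. For the measured compounds named here, that is the highest of the three numbers measured so far, but the other two sit close to it: compound 1, `O=C(Nc1cccc(-n2cc(-c3ccncc3)c(-c3cc(O)cc(Cl)c3)n2)c1)Nc1ccc(Cl)c(C(F)(F)F)c1`, gives 93%, and compound 2, `O=C(Nc1cccc(-n2cc(-c3ccncc3)c(-c3cc(O)cc(Cl)c3)n2)c1)Nc1ccc(Cl)c(Cl)c1`, gives 93%. The step of a number 4 percentage points higher from compound 1 to compound 3 (within the scatter) lies within the scatter, and the same holds for no change at the digits printed from compound 1 to compound 2 (within the scatter), so the three compounds cannot be told apart on these numbers.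

Compound 4, `COc1cc(Cl)cc(-c2nn(-c3cccc(NC(=O)Nc4ccc(Cl)c(Cl)c4)c3)cc2-c2ccncc2)c1`, differs from compound 3 in one place: chloro in place of trifluoromethyl on an aromatic carbon. This change has already been examined once among the measured compounds, because no change at the digits printed from compound 1 to compound 2 (within the scatter). Going by the values given here, the size of that step therefore gives the only guide, and it points to no movement beyond the scatter.

Compound 4 is accordingly expected to give about 95%, with a range from 85% to 104%. The step this estimate implies is a number 2 percentage points lower from compound 3 to compound 4 (within the scatter), expected to stay within the usual scatter.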

Compound 4, a percentage reported as activity, at one concentration (the size of the read-out at that concentration, not a potency): 100%
Compound 4: the middle estimate sits 5 percentage points below what was measured, within the range that was stated.
By their numbers in this assay, from the lowest: compounds 1, 2, 3 and 4 (each within the scatter of the next).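

The change from trifluoromethyl to chloro now has a second reading on a different core, a number 3 percentage points higher from compound 3 to compound 4 (within the scatter), and it agrees with the first: the same change on two cores in this assay, no change at the digits printed (within the scatter) from compound 1 to compound 2 and a number 3 percentage points higher (within the scatter) from compound 3 to compound 4, 3 percentage points apart, within the scatter of two such steps. Methyl in place of hydrogen on the oxygen also has a second reading in this assay, a number 7 percentage points higher from compound 2 to compound 4 (within the scatter), and it too agrees with the first: the same change on two cores in this assay, a number 4 percentage points higher (within the scatter) from compound 1 to compound 3 and a number 7 percentage points higher (within the scatter) from compound 2 to compound 4, 3 percentage points apart, within the scatter of two such steps. Neither change therefore moves the number beyond the scatter on either core tested, so the effect of each change shows no dependence on the other.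

The compounds shown carry only chloro or trifluoromethyl at this position, so what an amine or a carboxylic acid would do there remains open. On the oxygen they carry only hydrogen or methyl, which leaves a longer chain open as well.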